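Fluoro in place of hydrogen: what to expect for compound 4

This account rests on a few compounds, and the source may have more. Where it says the series, first, only, none or still open, it means among the compounds named here.

Compound 2 `Nc1sc(-c2ccccc2)c(-c2ccc(Cl)cc2)c1C(=O)NCc1ccccc1` gives 22800 nM in a functional assay on PC-3 cells (Homo sapiens) for cytotoxicity, read by sulforhodamine B assay, with a stated time of 72 h (on this read-out higher numbers stand for weaker inhibition and lower numbers for stronger inhibition), and so carries the highest of the three numbers at hand. Compound 1 `Nc1sc(-c2ccccc2)c(-c2ccc(Cl)cc2)c1C(=O)N1CCCC1` gives 22200 nM in this assay, and a 1.0-fold higher number from compound 1 to compound 2 (0.01 log units; within the scatter) shows that exchanging pyrrolidin-1-yl for benzylamino on the carbonyl carbon leaves the read-out essentially where it was. Among the compounds with values here, compound 3 `Nc1sc(-c2ccc(Cl)cc2)c(-c2ccc(Cl)cc2)c1C(=O)N1CCCC1` gives 6220 nM in this assay, and a 3.6-fold lower number from compound 1 to compound 3 (0.55 log units; beyond the scatter) is the only measured step in which a halogen replaces an aromatic hydrogen. Compound 4 `Nc1sc(-c2ccc(F)cc2)c(-c2ccc(Cl)cc2)c1C(=O)NCc1ccccc1` differs from compound 2 by fluoro in place of hydrogen on an aromatic carbon on an aromatic carbon of a six-membered aromatic ring of carbon only, para to a large group. The step from compound 1 to compound 3 therefore bears most directly on the question, while the step from compound 1 to compound 2 suggests the carbonyl substituent does not shift the response. With fluoro rather than chloro entering, a somewhat smaller fall is expected, so compound 4 is estimated at 12000 nM with a range from 5000 nM to 25000 nM in this assay, which would mean a 1.9-fold lower number from compound 2 to compound 4 (0.28 log units; within the scatter) as the expected step.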

Compound 4, half-maximal inhibitory concentration: 25800 nM
Estimate against measurement, compound 4: 2.2-fold (0.33 log units) below; the whole stated range lies below it.
By their numbers in this assay, from the lowest: compound 3; then compounds 1, 2 and 4 (each within the scatter of the next).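

In this assay, putting fluoro on the aromatic carbon para to a large group gives a 1.1-fold higher number from compound 2 to compound 4 (0.05 log units; within the scatter), so on the benzylamino amide, phenyl to 4-fluorophenyl leaves the number in place. The only earlier halogen step, a 3.6-fold lower number from compound 1 to compound 3 (0.55 log units; beyond the scatter), brought in chloro on the pyrrolidin-1-yl amide, so a halogen at this position does not move the read-out beyond the scatter in every case shown. Nothing available here accounts for this result.

The compounds shown leave open whether the difference between these two steps follows the halogen or the amide, since the two steps differ in both. They also leave open how bromo, methoxy or an amine at this position would read in this series.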